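Bromo for trifluoromethyl on a boron-containing chalcone

This account rests on a few compounds, and the source may have more. Where it says the series, first, only, none or still open, it means among the compounds named here.

Measured compounds:
- compound 1, `O=C(/C=C/c1ccc2c(c1)B(O)OC2)c1ccc(C(F)(F)F)cc1`: > 10 ug/mL
- compound 2, `O=C(/C=C/c1ccc2c(c1)B(O)OC2)c1ccc(Cl)c(Cl)c1`: > 10 ug/mL

Compound 1 was tested in an ADME assay on L929 cells (Mus musculus) for cytotoxicity, read by resazurin assay, with a stated time of 72 h; a lower number here means a stronger inhibitor, a higher number a weaker inhibitor. For compound 1 the reading of > 10 ug/mL is a limit of the assay, not a number. For compound 2 the reading of > 10 ug/mL is likewise a limit. Among the compounds with values here, compound 1 therefore stands at the limit of > 10 ug/mL in this assay, at which 2 of the 2 values shown sit, and the one further value shown is a limit as well, so no numerical difference between the two can be stated.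

Compound 3, `O=C(/C=C/c1ccc2c(c1)B(O)OC2)c1ccc(Br)cc1`, has not yet been tested in this assay. It differs from compound 1 by bromo in place of trifluoromethyl on an aromatic carbon. Within the data shown here, with both known values sitting at the limit, no step between measured compounds is available to guide the change. The step that the limit leaves unreadable from compound 1 to compound 3 is expected to stay within the usual scatter, with no clear direction. Compound 3 is estimated to give 15 ug/mL, with a range from 7 ug/mL to 40 ug/mL, and most likely to be reported as a limit again.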

Compound 3, half-maximal inhibitory concentration: > 10 ug/mL
Compound 3: no number, only a limit; the forecaster's own chance of this, stated with the estimate: 80%; the middle value lies beyond the limit too.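

In this assay compound 3 gives > 10 ug/mL, which is a limit and not a number. Within the data shown here, compound 1 also sits at a limit, so no step from compound 1 to compound 3 can be read. The compounds shown leave open how far any of them lies past that limit: the limit of > 10 ug/mL in this assay, at which 3 of the 3 values shown sit.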